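Benzimidazolylmethyl thioether replaces cyclohexylmethyl on triazolopyrimidine

The source may report more compounds than this note shows. Statements on the series, on what has been measured and on what is new or still open speak of the compounds shown alone.

Of the compounds shown here, three sharing one core have been tested in a functional assay on MGC-803 cells (Homo sapiens) for inhibition, read by MTT assay, with a stated time of 72 h; a higher number here means a weaker inhibitor, a lower number a stronger inhibitor. Compound 1 `Cc1cc(Nc2cc(-c3cccs3)[nH]n2)n2nc(SCc3ccc(Br)cc3)nc2n1` gives 3770 nM. Compound 2 `Cc1cc(Nc2cc(-c3ccccc3)[nH]n2)n2nc(SCC3CCCCC3)nc2n1` gives 12600 nM. Compound 3 `CCCCCc1c(C)nc2nc(SCc3ccc(Cl)cc3)nn2c1Nc1cc(-c2ccccc2)[nH]n1` gives 7140 nM. Compound 2 is set apart from compound 1 by a gap beyond the usual scatter, so compound 2 is the weaker inhibitor of that pair; its gap to compound 3 lies within the scatter, and nothing can be said of their order.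

The next step keeps the core of compound 2 and alters the group on the sulfur-bound saturated chain carbon: 1H-benzimidazol-2-yl in place of cyclohexyl on a saturated chain carbon bound to a sulfur. The result is compound 4 `Cc1cc(Nc2cc(-c3ccccc3)[nH]n2)n2nc(SCc3nc4ccccc4[nH]3)nc2n1`, not yet measured in this assay.

Compound 1 carries an aromatic ring on the same chain carbon and gives 3770 nM. Within the data shown here, its gap to compound 2 lies beyond the scatter, with compound 1 on the stronger side, and this is the only guide available. On that basis the step is expected to run toward stronger inhibition by about a 2.3-fold lower number from compound 2 to compound 4 (0.36 log units; beyond the scatter), a moderate step not far beyond the scatter. Compound 4 is therefore estimated at 5500 nM, with a range from 2000 nM to 15000 nM.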

Compound 4, half-maximal inhibitory concentration: 1790 nM
Estimate against measurement, compound 4: 3.1-fold (0.49 log units) above; measured number outside the range, below it.
By their numbers in this assay, from the lowest: compound 4; then compounds 1, 3 and 2 (each within the scatter of the next, the first and the last beyond it).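

In this assay, among these compounds, 1H-benzimidazol-2-yl in place of cyclohexyl on a saturated chain carbon bound to a sulfur gives a 7.0-fold lower number from compound 2 to compound 4 (0.85 log units; beyond the scatter), the first reading in this set of a change made in one place alone. It shows that, with the rest of compound 2 held fixed, the group on this chain carbon affects the measured inhibition, and that a larger group with two aromatic rings, nitrogen atoms and a hydrogen-bond donor and acceptor is compatible with stronger inhibition than cyclohexyl. The entering group differs from cyclohexyl in all of these features at once, and no accompanying data show which of them accounts for the step.

The compounds shown leave open whether the aromatic rings alone go with the stronger inhibition or whether the ring nitrogen atoms also contribute. A phenyl, a 1H-indol-2-yl or a 1-methyl-1H-benzimidazol-2-yl group on the same chain carbon would begin to separate these features, and a longer chain between the sulfur and the 1H-benzimidazol-2-yl group would test how much the length of the link matters.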